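Compound 3: methyl for methoxy at the assay limit

This account rests on a few compounds, and the source may have more. Where it says the series, first, only, none or still open, it means among the compounds named here.

Of the compounds shown here, two have been measured in a functional assay on Jurkat cells (Homo sapiens) for cytotoxicity, with a stated time of 24 h; on this read-out lower numbers stand for stronger inhibition and higher numbers for weaker inhibition. Compound 1 `Nn1c(SCc2ccccc2)nnc1-c1c[nH]c2ccccc12` gives > 100000 nM, which is a limit and not a number. Going by these compounds, compound 2 `COc1ccc(CSc2nnc(-c3c[nH]c4ccccc34)n2N)cc1` gives > 100000 nM, which is also a limit and not a number, so its true position is unknown. The evidence available is the limit of > 100000 nM in this assay, at which 2 of the 2 values shown sit.

Compound 3 `Cc1ccc(CSc2nnc(-c3c[nH]c4ccccc34)n2N)cc1` differs from compound 2 as follows: methyl in place of methoxy on an aromatic carbon. This places methyl in place of methoxy on an aromatic carbon.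

Among the measured compounds shown here, the only measured step that bears on this change is a step that the two limits leave unreadable from compound 1 to compound 2, and it has no readable size. Nothing measured therefore points to a step beyond the scatter in this assay, in either direction. The expected step is a number no higher from compound 2 to compound 3 (the limit leaves the size open). For compound 3 the estimate is 100000 nM, with an expected range of 50000 nM to 200000 nM, and a report as a limit is the likeliest outcome.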

Compound 3, half-maximal inhibitory concentration: > 100000 nM
Compound 3: only a limit was reported; the forecaster's own chance of this, stated with the estimate: 85%; the middle value lies on the limit itself.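

In this assay compound 3 gives > 100000 nM, a limit and not a number. Among the compounds shown here, no step among compound 1, compound 2 and compound 3 can be read. The compounds shown leave open how hydrogen, methoxy and methyl compare on that aromatic carbon, as none has a measured number: the limit of > 100000 nM in this assay, at which 3 of the 3 values shown sit.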